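Oxan-4-yl in place of 1,3-oxazol-4-yl: compound 4

The source may report more compounds than this note shows. Statements on the series, on what has been measured and on what is new or still open speak of the compounds shown alone.

In a physicochemical assay for lipophilicity, read by HPLC (on this read-out higher numbers stand for higher lipophilicity and lower numbers for lower lipophilicity), compound 1 `CCn1c(-c2cnc(C)nc2)nc2c(N[C@H]3CCN(C(=O)c4cocn4)C3)ncnc21` gives 0.6, the lowest of the three numbers; compound 3 `CCn1c(-c2cnc(C)nc2)nc2c(O[C@H]3CCN(C(=O)C4CCOC4)C3)ncnc21` gives 0.7, within the scatter of compound 1, and compound 2 `CCn1c(-c2cnc(C)nc2)nc2c(O[C@H]3CCN(C(=O)C4CC(F)(F)C4)C3)ncnc21` gives 1.5, beyond it. Compound 4 `CCn1c(-c2cnc(C)nc2)nc2c(N[C@H]3CCN(C(=O)C4CCOCC4)C3)ncnc21` differs from compound 1 on the carbonyl carbon whose other neighbour is the amide-type nitrogen in a ring: oxan-4-yl in place of 1,3-oxazol-4-yl on a carbonyl carbon. Among the compounds with values here, the only measured step on that carbonyl carbon, a number 0.80 log units lower from compound 2 to compound 3 (beyond the scatter), exchanges two other rings and bears on this change only loosely. Within the data shown here, no measured step removes 1,3-oxazol-4-yl. The step expected is a number 0.50 log units higher from compound 1 to compound 4 (beyond the scatter), a modest rise beyond the scatter. Compound 4 is therefore estimated at 1.1, between 0.6 and 1.6.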

Compound 4, distribution coefficient: 0.7
For compound 4 the middle estimate is 0.40 log units above the measured one; the range from low to high includes it.
By their numbers in this assay, from the lowest: compounds 1, 3 and 4 (each within the scatter of the next); then compound 2.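

In this assay, oxan-4-yl in place of 1,3-oxazol-4-yl on a carbonyl carbon gives a number 0.10 log units higher from compound 1 to compound 4 (within the scatter), so at this position the read-out does not separate a five-membered aromatic ring with 2 hetero atoms from a six-membered non-aromatic ring with 1 hetero atom. Within the data shown here, the one earlier step on such a carbonyl carbon, a number 0.80 log units lower from compound 2 to compound 3 (beyond the scatter), shows that a ring exchange there can move the number; this exchange does not. No supporting evidence bears on the result.

The compounds shown carry only rings on that carbonyl carbon. Going by these compounds, how a longer alkyl chain or an amine there would read in this assay stays open.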